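From Compound 2 to Compound 3: Replacing the Acetyl Group

This account rests on a few compounds, and the source may have more. Where it says the series, first, only, none or still open, it means among the compounds named here.

Of the compounds shown here, two that share one core have been measured so far in a functional assay (trachea) with Cavia porcellus as the target; a lower number here means a stronger inhibitor, a higher number a weaker inhibitor. In this test, compound 1 `CCn1nc(-c2cccnc2)c2ccccc2c1=O` gives 1320 nM. Compound 2 `CC(=O)Cn1nc(-c2cccnc2)c2ccccc2c1=O` gives 40700 nM, the higher of the two numbers, which makes it the weaker inhibitor of the pair.

The next compound, compound 3 `O=c1c2ccccc2c(-c2cccnc2)nn1CCSc1nccs1`, carries ((1,3-thiazol-2-yl)sulfanyl)methyl in place of acetyl on a saturated chain carbon bound to an aromatic nitrogen. Counted group by group, the change reads (((1,3-thiazol-2-yl)sulfanyl)methyl in place of acetyl on a saturated chain carbon bound to an aromatic nitrogen).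

Among the measured compounds shown here, the one measured step that bears on this is a 31-fold higher number from compound 1 to compound 2 (1.49 log units; beyond the scatter), large and beyond the scatter. It came with acetyl in place of methyl, so losing the acetyl may undo part of it. For the measured compounds named here, no measured compound carries the entering group, however, so how much returns is uncertain. A move toward a lower number is therefore expected in this assay, smaller than the earlier rise, and the estimate is a 6.8-fold lower number from compound 2 to compound 3 (0.83 log units; beyond the scatter). For compound 3 the estimated value is 6000 nM, with an expected range from 1000 nM to 35000 nM.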

Compound 3, half-maximal inhibitory concentration: 10500 nM
For compound 3 the middle estimate is 1.8-fold (0.24 log units) below the measured one; the range from low to high includes it.
By their numbers in this assay, from the lowest: compound 1; then compound 3; then compound 2.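

In this assay, ((1,3-thiazol-2-yl)sulfanyl)methyl in place of acetyl gives a 3.9-fold lower number from compound 2 to compound 3 (0.59 log units; beyond the scatter), so this place on the chain can carry a group with more heavy atoms than acetyl and still give a lower number than compound 2 does. The recovery is only partial: adding (1,3-thiazol-2-yl)sulfanyl in place of hydrogen on a saturated chain carbon, two bonds along the chain from an aromatic nitrogen, gives an 8.0-fold higher number from compound 1 to compound 3 (0.90 log units; beyond the scatter), which leaves compound 1, with its plain ethyl chain, as the strongest inhibitor of the three. No measurement at hand explains why either change moves the number as it does.

Compounds 2 and 3 differ in the whole group at the end of the chain, so these results cannot separate the part played by the sulfur link from that of the thiazole ring. On these data alone, it also remains open how this place would respond to a longer plain carbon chain, an amine, a carboxylic acid, or a phenyl ring attached directly to the chain.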